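A few compounds are considered here, and "the series" means these few. Any claim that something is new, unique, unknown or untested is made for them only; others in the source may bear on it.

Measured so far in a functional assay on CHO cells for agonist activity at Alpha-1A adrenergic receptor (Homo sapiens), read by FLIPR and calcium flux; a higher number here means a larger maximal response, a lower number a smaller maximal response:

Compound 1, `Fc1ccccc1C1Cc2nccn2C1`: 63%
Compound 2, `c1ccc(C2Cc3nccn3C2)cc1`: 80%; 74%; 25%; 85% (4 entries)
Compound 3, `NC(=O)c1ccccc1C1Cc2nccn2C1`: 87%

Compound 3 gives the highest of the two single numbers in this assay; the nearest is compound 1, and the step of a number 24 percentage points higher from compound 1 to compound 3 (beyond the scatter) lies beyond the scatter. Compound 2 has several entries rather than one number, and they spread widely, as the several entries of compound 2 in this assay, 80%; 74%; 25%; 85% (4 entries) shows.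

Compound 4, `FC(F)Oc1ccccc1C1Cc2nccn2C1`, has not yet been measured. It differs from compound 3 in one place: difluoromethoxy in place of carbamoyl on an aromatic carbon.

Within the data shown here, only one measured step bears on this change. The step of a number 24 percentage points higher from compound 1 to compound 3 (beyond the scatter) shows that putting carbamoyl in place of fluoro on the aromatic carbon raised the maximal response by a modest amount. Compound 4 now removes the carbamoyl again and puts difluoromethoxy in its place. Among the measured compounds shown here, no measured step covers difluoromethoxy directly, so the expectation rests on undoing the carbamoyl gain, and the wide spread of compound 2 in the several entries of compound 2 in this assay, 80%; 74%; 25%; 85% (4 entries) warns that any single number may scatter.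

A modest downward step is therefore expected, a number 22 percentage points lower from compound 3 to compound 4 (beyond the scatter). Compound 4 is estimated to reach 65% in this assay, with a range from 40% to 88%.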

Compound 4, largest response reached (Emax), in percent of the reference or control that the assay uses in the Alpha-1A adrenergic receptor assay: 75%
Compound 4: the middle estimate sits 10 percentage points below what was measured; low and high end bracket the measured number.
By their numbers in the Alpha-1A adrenergic receptor assay, from the lowest: compound 1; then compound 4; then compound 3.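

In the Alpha-1A adrenergic receptor assay, difluoromethoxy in place of carbamoyl on this aromatic carbon gives a number 12 percentage points lower from compound 3 to compound 4 (beyond the scatter), while difluoromethoxy in place of fluoro gives a number 12 percentage points higher from compound 1 to compound 4 (beyond the scatter). Among these three compounds the response therefore rises from fluoro through difluoromethoxy to carbamoyl, and the hydrogen-bond donor that carbamoyl carries and difluoromethoxy lacks is not needed for a response above that of compound 1. Among these compounds, in a physicochemical assay for lipophilicity, at pH 7.4 (on this read-out lower numbers stand for lower lipophilicity and higher numbers for higher lipophilicity), compound 4 gives 2.3 and the entry for compound 3 reads "not determined" (no result reported), so no step between them can be read on this scale.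

On these data alone, it remains open how the response would change with an amine, a carboxylic acid or a longer chain such as ethoxy on this aromatic carbon, since these three groups alone cannot show what the order depends on. The comparison with compound 2, which carries no group at this place, also stays open, as its entries spread too widely to give one number: the several entries of compound 2 in the Alpha-1A adrenergic receptor assay, 80%; 74%; 25%; 85% (4 entries)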